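Cyanoguanidine chain isomers on the shared core

A few compounds are considered here, and "the series" means these few. Any claim that something is new, unique, unknown or untested is made for them only; others in the source may bear on it.

Three compounds of the series carry numbers in a functional assay on the whole organism with Rattus norvegicus as the target, at a dose of 100 mg/kg; on this read-out higher numbers stand for more inhibition at the one dose given (going by the name of the read-out) and lower numbers for less inhibition. Compound 1 `C/N=C(/NC#N)NCCCCCCn1nc(-c2ccccc2)ccc1=O` gives 31.7% and stands second highest of the three. Compound 2 `CCC/N=C(/NC#N)NCCCn1nc(-c2ccccc2)ccc1=O` gives 52.9%, which lies above compound 1 by a gap beyond the scatter. Compound 3 `C/N=C(\S)N(C)CCCCn1nc(-c2ccccc2)ccc1=O`, the thiourea member, gives 17.5%, below compound 1 by a gap also beyond the scatter.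

Compound 4 `CC/N=C(/NC#N)NCCCCCn1nc(-c2ccccc2)ccc1=O` has not yet been measured in this assay. It has the same atoms as compound 1, joined differently: a group of 8 heavy atoms (4 carbon, 4 nitrogen; no ring) in place of a group of 8 heavy atoms (4 carbon, 4 nitrogen; no ring), on a saturated chain carbon, five bonds along the chain from an aromatic nitrogen. Going by the values given here, no pair of measured compounds differs in one place alone, so no single-change step is available as a guide. The two cyanoguanidines, compound 1 and compound 2, bracket the region where compound 4 is expected to fall, with the chain and the substituent on the cyanoguanidine of compound 4 sitting between those two.

Compound 4 is estimated at 42%, within 25% to 60%. The expected step of a number 10.3 percentage points higher from compound 1 to compound 4 (beyond the scatter) is a modest rise, and it may not exceed the scatter.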

Compound 4, a percentage reported as inhibition, in the whole organism at one dose (the size of the read-out at that dose, not a potency): 48.2%
Beside the measured number, compound 4's estimate is 6.2 percentage points below it, and the stated range covers the measured number.
By their numbers in this assay, from the lowest: compound 3; then compound 1; then compounds 4 and 2 (each within the scatter of the next).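

On a saturated chain carbon, five bonds along the chain from an aromatic nitrogen, exchanging one group of 8 heavy atoms for another gives, in this assay, a number 16.5 percentage points higher from compound 1 to compound 4 (beyond the scatter). Going by these compounds alone, both groups have the same counts of heavy atoms, double and triple bonds, hydrogen-bond donors and acceptors, and neither has a net charge, so a different joining of the same atoms is enough to shift this read-out, which the earlier compounds, with no single-change step among them, could not show. No measured property is available that bears on this shift.

Still open, going by these compounds, is how the read-out responds when an amine or a urea takes the place of the cyanoguanidine on the chain of compound 4. A single dose also leaves open whether the step would hold at other doses.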